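The source may report more compounds than this note shows. Statements on the series, on what has been measured and on what is new or still open speak of the compounds shown alone.

Of the compounds shown here, two have so far been measured in an assay on HeLa cells for inhibition of histone deacetylase 8 (Homo sapiens), read by fluorescence, with a stated time of 30 min; on this read-out higher numbers stand for weaker inhibition and lower numbers for stronger inhibition. Within the data shown here, compound 2 `O=C(CCCCOc1cccc(-c2nnc(-c3ccccc3)s2)c1)NO` gives 3110 nM in this assay, and this is the only number in hand. Compound 1 `O=C(CCCCCCOc1ccc(-c2nnc(-c3ccccc3)s2)cc1)NO` reaches only a limit in this assay, > 10000 nM, so that one of the two results sits at the limit of > 10000 nM in this assay, at which 1 of the 2 values shown sits. Compound 3 `O=C(CCCCCOc1cccc(-c2nnc(-c3ccccc3)s2)c1)NO` has not yet been measured. It differs from compound 2 in a single place: (hydroxycarbamoyl)methyl in place of hydroxycarbamoyl on a saturated chain carbon, four bonds along the chain from an oxygen on an aromatic ring. Among the measured compounds shown here, no measured pair shows a change of this kind, so the size of the step is open. The lengthening of the chain is expected to shift the result only modestly, if at all, and in this assay compound 3 is estimated at 4500 nM, within a range from 1500 nM to 13000 nM. This amounts to an expected step of a 1.4-fold higher number from compound 2 to compound 3 (0.16 log units; within the scatter), which would lie within the usual scatter.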

Compound 3, half-maximal inhibitory concentration: 3030 nM
The estimate for compound 3 lay 1.5-fold (0.17 log units) above the measured number, within the range that was stated.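

Among these compounds, this is the first measured step at this position, and it puts a size on the change: in this assay, (hydroxycarbamoyl)methyl in place of hydroxycarbamoyl gives a 1.0-fold lower number from compound 2 to compound 3 (0.01 log units; within the scatter). That step lies within the usual scatter, so this assay cannot tell compound 2 and compound 3 apart, and the added carbon has no effect that this read-out can detect. Nothing in the data at hand accounts for this result.

This single pair shows only what happens over this one change on the chain, so it sets no trend for chain length in general. A longer chain, such as 4-(hydroxycarbamoyl)butyl extended further, might give a different number, and a carboxylic acid in place of the hydroxycarbamoyl end remains an open question.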